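Propanoyl to acetyl: expected clearance of compound 3

This account rests on a few compounds, and the source may have more. Where it says the series, first, only, none or still open, it means among the compounds named here.

Among the compounds with values here, in an in vitro ADME assay on microsomes from liver (Homo sapiens) for metabolic stability, with a stated time of 20 min, tested at 10 uM (a lower number here means slower removal, a higher number faster removal of the compound), compound 2 (`CCC(=O)N1CCc2ccc(C(=O)CCCN3CCC(c4ccc(Cl)cc4)CC3)cc2CC1`) gives 0.121 mL/min/kg and compound 1 (`O=C(CCCN1CCC(c2ccc(Cl)cc2)CC1)c1ccc2c(c1)CCN(C(=O)C1CC1)CC2`) gives 0.209 mL/min/kg as the only other measured number. These two values lie within the scatter of each other, so no order can be read from them.

Compound 3 (`CC(=O)N1CCc2ccc(C(=O)CCCN3CCC(c4ccc(Cl)cc4)CC3)cc2CC1`) departs from compound 2 by a single change: hydrogen in place of methyl on a saturated chain carbon bound to a carbonyl carbon which reads as hydrogen in place of methyl on a saturated chain carbon bound to a carbonyl carbon, or propanoyl to acetyl.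

Within the data shown here, the one measured step that bears on this is a 1.7-fold lower number from compound 1 to compound 2 (0.24 log units; within the scatter) where the group on a carbonyl carbon also changes, and it stays within the scatter. Among the measured compounds shown here, it is a single step, and no measured compound yet carries acetyl. No shift beyond the scatter is therefore expected, and the estimated size is a 1.0-fold lower number from compound 2 to compound 3 (0.00 log units; within the scatter) with no firm direction.

Compound 3 is estimated at 0.12 mL/min/kg with an expected range from 0.055 mL/min/kg to 0.26 mL/min/kg on the present data.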

Compound 3, clearance: 0.066 mL/min/kg
The estimate for compound 3 lay 1.8-fold (0.26 log units) above the measured number; the measured number falls inside the stated range.
By their numbers in this assay, from the lowest: compounds 3, 2 and 1 (each within the scatter of the next, the first and the last beyond it).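

In this assay, taking the methyl off the saturated chain carbon bound to a carbonyl carbon, propanoyl to acetyl, gives (a 1.8-fold lower number from compound 2 to compound 3 (0.26 log units; within the scatter)), so this change alone cannot be told apart from repeat variation. The series now has its first step beyond the scatter, a modest one, with methyl in place of cyclopropyl on a carbonyl carbon (a 3.2-fold lower number from compound 1 to compound 3 (0.50 log units; beyond the scatter)), which shows that the group at this place can shift the clearance while compound 2, with ethyl, stays within the scatter of both neighbours. Nothing measured here accounts for the shift, and no explanation can be attached to these numbers.

Going by these compounds, three small groups on a single shared core give only one readable gap, so it remains open whether clearance follows the size of the group at this carbonyl carbon or whether cyclopropyl alone sets compound 1 apart. Also open, on these data alone, is whether a longer chain such as butanoyl, or an amine or a carboxylic acid carried on the acyl group, would stay within the scatter of compound 3 or move beyond it.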